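A few compounds are considered here, and "the series" means these few. Any claim that something is new, unique, unknown or untested is made for them only; others in the source may bear on it.

Within the data shown here, in an ADME assay on microsomes from liver (Mus musculus) for metabolic stability, read by LC-MS, with a stated time of 10 min, tested at 0.5 uM (a higher number here means that more of the compound is left, a lower number that less of the compound is left), only two compounds have numbers so far. Compound 1 `c1ccc2c(c1)CN[C@@H](CN(CC1CCNCC1)[C@H]1CCCc3cccnc31)C2` gives 13%, while compound 2 `c1cnc2c(c1)CN[C@H](CN(CCCN1CCNCC1)[C@H]1CCCc3cccnc31)C2` gives 63%, the higher of the two, and the gap between them lies beyond the usual scatter. These two compounds differ in more than one place, so their gap says little about any single change. Compound 3 `c1cnc(CN(CCCN2CCNCC2)[C@H]2CCCc3cccnc32)nc1` has not yet been measured, and it departs from compound 2 in one place: a group of 6 heavy atoms (4 carbon, 2 nitrogen; one six-membered aromatic ring with 2 hetero atoms) in place of a group of 10 heavy atoms (8 carbon, 2 nitrogen; one six-membered non-aromatic ring with 1 hetero atom, one six-membered aromatic ring with 1 hetero atom), on a saturated chain carbon bound to an amine nitrogen. Among the measured compounds shown here, no measured pair shows this exchange, so the expectation starts from the 63% of compound 2 and remains loose. The estimated change is a number 5 percentage points higher from compound 2 to compound 3 (within the scatter), a small upward move that may well stay within the scatter. For compound 3 the estimate is 68%, with an expected range from 43% to 90%.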

Compound 3, percent of the compound remaining: 78%
Compound 3: middle estimate off by 10 percentage points, on the low side; the measured number falls inside the stated range.
By their numbers in this assay, from the lowest: compound 1; then compound 2; then compound 3.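

In this assay, among these compounds, the exchange gives a number 15 percentage points higher from compound 2 to compound 3 (beyond the scatter), the first reading of a single change, whereas compound 1 and compound 2 differ in more than one place. It shows that, on a saturated chain carbon bound to an amine nitrogen, pyrimidin-2-yl, a single aromatic ring of fewer heavy atoms, can replace the two-ring group of compound 2 with more of the compound left, not less. No evidence at hand accounts for this step.

The compounds shown do not separate the smaller size of the entering group from its second ring nitrogen, a question that a phenyl or pyridin-2-yl group at this place would address. Going by these compounds, whether the exchange would give a similar step on the side chain of compound 1 also stays open.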